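The source may report more compounds than this note shows. Statements on the series, on what has been measured and on what is new or still open speak of the compounds shown alone.

Compound 1: `CCCN(CC1CC1)c1c(C)nc(-c2c(C)cc(C)cc2OC)c2ccccc12`. In a physicochemical assay for solubility, at pH 5.4 (on this read-out lower numbers stand for lower solubility and higher numbers for higher solubility), compound 1 gives < 0.5 ug/mL, which is a limit of the assay and not a number.
Compound 2: `COc1cc(C)cc(C)c1-c1nc(C)c(N(CC2CC2)CC2CC2)c2ccccc12`. In this assay compound 2 gives < 0.5 ug/mL, again a limit of the assay rather than a number.

Among the measured compounds shown here, compound 2 therefore stands at the floor of what this assay can report, and so does its only measured neighbour: the limit of < 0.5 ug/mL in this assay, at which 2 of the 2 values shown sit. For the measured compounds named here, the one measured step, a step that the two limits leave unreadable from compound 1 to compound 2, is unreadable for that reason, since both ends sit at the same limit, and it gives no size and no direction.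

The next compound, compound 3, is `CCCN(CCC)c1c(C)nc(-c2c(C)cc(C)cc2OC)c2ccccc12`. It differs from compound 2 in one place: dipropylamino in place of bis(cyclopropylmethyl)amino on an aromatic carbon.

Going by the values given here, no measured step touches this change, and the only step on record, a step that the two limits leave unreadable from compound 1 to compound 2, cannot be read, so the expectation rests on where compound 2 stands rather than on any trend. The step from compound 2 to compound 3 is expected to be a number no lower from compound 2 to compound 3 (the limit leaves the size open), most likely leaving compound 3 at or near the same limit. The estimate for compound 3 is 0.5 ug/mL, with a range from 0.2 ug/mL to 2 ug/mL.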

Compound 3, solubility: < 0.5 ug/mL
Compound 3 was reported as a limit; the forecaster's own chance of this, stated with the estimate: 60%; the middle value sits exactly at the limit.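

In this assay compound 3 gives < 0.5 ug/mL, which is a limit of the assay and not a number. The steps among compound 1, compound 2 and compound 3 therefore cannot be read, since all three sit at the same floor: the limit of < 0.5 ug/mL in this assay, at which 3 of the 3 values shown sit. The compounds shown leave open whether swapping these amino groups changes the read-out at all.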